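Acetyl versus cyano on the indole series

The compounds below may be only part of what the source reports. "The series", "measured", "known", "first", "only" and "open" are said of these compounds alone.

Measured so far in a functional assay on BT-549 cells (Homo sapiens) for inhibition, read by sulforhodamine B assay, with a stated time of 48 h; a lower number here means a stronger inhibitor of growth, a higher number a weaker inhibitor of growth:
compound 1 `COc1ccc(-c2[nH]c3ccc(OC)cc3c2/C=C(\C#N)S(=O)(=O)c2ccccc2)cc1`: 4800 nM
compound 2 `CC(=O)/C(=C\c1c(-c2ccccc2)[nH]c2ccccc12)S(=O)(=O)c1ccccc1`: 1900 nM

Compound 2 holds the lowest of the two numbers measured in this assay; the nearest is compound 1, whose value lies higher by more than the usual scatter. Compound 1 and compound 2 differ in several places at once, so no single step can be read from that pair.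

Compound 3 `N#C/C(=C\c1c(-c2ccccc2)[nH]c2ccccc12)S(=O)(=O)c1ccccc1` has not been measured. It differs from compound 2 in one place: cyano in place of acetyl on a double-bonded chain carbon bound to a double-bonded chain carbon and a sulfonyl sulfur. Compound 1 also carries a cyano at that position, but with further changes elsewhere, so its value is only a loose point of reference. The step of a 1.3-fold higher number from compound 2 to compound 3 (0.12 log units; within the scatter) is expected to be small, at most a modest rise, within or just at the edge of the scatter. For compound 3 the value in this assay is estimated at 2500 nM, with a range from 900 nM to 7000 nM.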

Compound 3, concentration for 50% growth inhibition: 11600 nM
Compound 3: middle estimate off by 4.6-fold (0.67 log units), on the low side; the whole stated range lies below it.
By their numbers in this assay, from the lowest: compound 2; then compound 1; then compound 3.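

In this assay, the position on a double-bonded chain carbon bound to a double-bonded chain carbon and a sulfonyl sulfur proves sensitive: cyano in place of acetyl gives a 6.1-fold higher number from compound 2 to compound 3 (0.79 log units; beyond the scatter) with the rest of the structure unchanged. Going by these compounds alone, this is the first single-place step, and on this core it puts acetyl ahead of cyano, which the pair of compound 1 and compound 2 could not show. Nothing on hand bears on why the step arises.

On these data alone, whether the lower number is particular to acetyl stays open: a propanoyl group, a methyl ester or a primary amide at this position would show whether a longer chain or another carbonyl-bearing group holds it. Whether the same step would appear on the core of compound 1 also stays open, since that core is shown only with cyano.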